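A few compounds are considered here, and "the series" means these few. Any claim that something is new, unique, unknown or untested is made for them only; others in the source may bear on it.

Measured compounds:
- Compound 1, `COc1cc(N(CC2CC2)c2ccc(Cl)c3ccccc23)cnc1C(=O)[C@H]1C[C@@H]1C(=O)O` — 5 uL/min
- Compound 2, `COc1cc(N(CC(C)C)c2ccc(F)c3ccccc23)cnc1C(=O)[C@H]1C[C@@H]1C(=O)O` — 56 uL/min

In an ADME assay on cells (Hepatocyte, Homo sapiens) for metabolic stability, read by LC-MS, with a stated time of 60 min, tested at 1 uM (a lower number here means slower removal, a higher number faster removal of the compound), compound 2 gives 56 uL/min, the higher of the two numbers recorded so far. Compound 1 gives 5 uL/min in this assay, a gap that lies well beyond the usual scatter, so compound 2 stands as the faster-cleared of the two.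

Compound 3, `CCN(c1cnc(C(=O)[C@H]2C[C@@H]2C(=O)O)c(OC)c1)c1ccc(F)c2ccccc12`, has not yet been measured in this assay. It differs from compound 2 in one place: methyl in place of isopropyl on a saturated chain carbon bound to a nitrogen on an aromatic ring. The two compounds differ in nothing else.

For the measured compounds named here, no measured pair in this set shares this change, so the step can only be expected, not read off. With a smaller alkyl group on the chain, the author expects a moderate downward step of a 1.6-fold lower number from compound 2 to compound 3 (0.20 log units; within the scatter), of a size that may or may not exceed the scatter. Compound 3 is therefore estimated at 35 uL/min in this assay, with a range from 14 uL/min to 85 uL/min.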

Compound 3, intrinsic clearance in a liver preparation (reported as CLH), per the amount of preparation that the assay uses in the Hepatocyte assay: 3.8 uL/min
For compound 3 the middle estimate is 9.2-fold (0.96 log units) above the measured one; the whole stated range lies above it.
By their numbers in the Hepatocyte assay, from the lowest: compounds 3 and 1 (each within the scatter of the next); then compound 2.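

At this place, on a saturated chain carbon bound to a nitrogen on an aromatic ring, methyl in place of isopropyl proves to be a large change: in the Hepatocyte assay the result is a 15-fold lower number from compound 2 to compound 3 (1.17 log units; beyond the scatter). In a physicochemical assay for lipophilicity, read by LC-MS, in phosphate buffer, measured as octanol-water partition, at pH 7.4 (on this read-out higher numbers stand for higher lipophilicity and lower numbers for lower lipophilicity), compound 2 reads 2.2 and compound 3 reads 1.4, so this change moves both read-outs in the same direction. The lower clearance of compound 3 goes together with its lower lipophilicity: the measured distribution coefficient of compound 2, 2.2, and of compound 3, 1.4, a number 0.80 log units lower (beyond the scatter)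

A single pair cannot tell whether lipophilicity accounts for the whole step in clearance or whether the chain itself also matters. The compounds shown also leave open how a propyl chain, or a chain carrying a hydroxyl group or an amine, would behave at this place.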